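Swapping Methoxy for Fluoro on a Benzyl Arm

The source may hold more compounds than are shown below. What is called first, only, known or untested is meant among the compounds shown, and "the series" means these compounds.

Three compounds sharing one core have been measured in an assay on isolated protein for inhibition of aldehyde dehydrogenase 1A1 (Homo sapiens), read by spectrophotometry, tested at 10 uM; a lower number here means less inhibition, a higher number more inhibition at the concentration tested (going by the name of the read-out):
Compound 1, `CC(C)=CCn1c(CN2CCN(C(=O)C3CC3)CC2)nc2ccccc21`, gives 74.3%.
Compound 2, `Cc1ccc(Cn2c(CN3CCN(C(=O)C4CC4)CC3)nc3ccccc32)cc1`, gives 51.5%.
Compound 3, `COc1cccc(Cn2c(CN3CCN(C(=O)C4CC4)CC3)nc3ccccc32)c1`, gives 44.4%.

Compound 3 stands lowest of the three numbers. Its gap to compound 1 is the largest, a number 29.9 percentage points lower from compound 1 to compound 3 (beyond the scatter), and that step is beyond the scatter. Its gap to compound 2, a number 7.1 percentage points lower from compound 2 to compound 3 (within the scatter), is within the scatter, so compounds 2 and 3 cannot be told apart on these numbers.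

Compound 4, `O=C(C1CC1)N1CCN(Cc2nc3ccccc3n2Cc2cccc(F)c2)CC1`, has not yet been measured. It differs from compound 3 in one place: fluoro in place of methoxy on an aromatic carbon.

For the measured compounds named here, no measured step changes a substituent on the aromatic ring while keeping the rest fixed, so no step speaks directly to this swap. The nearest evidence is a number 7.1 percentage points lower from compound 2 to compound 3 (within the scatter), where one substituted phenyl replaced another and the number stayed within the scatter. By that analogy the exchange of methoxy for fluoro is expected to leave the read-out close to that of compound 3, with no step beyond the scatter in either direction, so the expected step is a number 0.6 percentage points higher from compound 3 to compound 4 (within the scatter). Compound 4 is therefore estimated at 45%, with a range from 25% to 65%.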

Compound 4, a percentage reported as inhibition, at one concentration (the size of the read-out at that concentration, not a potency): 27.2%
The estimate for compound 4 lay 17.8 percentage points above the measured number; measured number inside the range.
By their numbers in this assay, from the lowest: compound 4; then compounds 3 and 2 (each within the scatter of the next); then compound 1.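

At this place on the ring the substituent does matter in this assay: holding everything else fixed, changing 3-methoxybenzyl to 3-fluorobenzyl gives a number 17.2 percentage points lower from compound 3 to compound 4 (beyond the scatter) and so separates two compounds that differ by a single small group, whereas the earlier exchange of one substituted phenyl for another stayed within the scatter. The 3-fluorophenyl arm also stands apart from the 4-methylphenyl arm, with a number 24.3 percentage points lower from compound 2 to compound 4 (beyond the scatter) to show for it, and further still from the 2-methylprop-1-en-1-yl arm, with a number 47.1 percentage points lower from compound 1 to compound 4 (beyond the scatter) as the widest gap, which makes compound 4 the lowest of the four on inhibition at the concentration tested. No measurement at hand explains why this exchange lowers the number.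

On these data alone, what stays open is whether the fall follows from the arrival of fluoro or from the departure of methoxy, a question that a plain unsubstituted benzyl arm, or a chloro or hydroxy group at this same place, would help to settle. As far as these compounds go, it is also open whether fluoro on another carbon of the ring would give a similar number.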